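This account rests on a few compounds, and the source may have more. Where it says the series, first, only, none or still open, it means among the compounds named here.

Compound 1 `Cc1ccc(NC2=CC(=O)c3nc4n(c3C2=O)[C@H]2OC[C@@H](O)[C@H]2OC4)cc1` carries a 4-methylphenyl group on an amine nitrogen. In a functional assay on MGC-803 cells (Homo sapiens) for inhibition, read by sulforhodamine B assay (on this read-out higher numbers stand for weaker inhibition and lower numbers for stronger inhibition), compound 1 gives 1420 nM. Compound 2 `O=C1C(Nc2cccc(Cl)c2)=CC(=O)c2c1nc1n2[C@H]2OC[C@@H](O)[C@H]2OC1` carries a 3-chlorophenyl group on that nitrogen instead, and in this assay compound 2 gives 1530 nM, so the two numbers lie within the usual scatter of each other. Compound 3 `O=C1C(NC2CC2)=CC(=O)c2c1nc1n2[C@H]2OC[C@@H](O)[C@H]2OC1` carries a cyclopropyl group on the nitrogen, and in this assay compound 3 gives > 4000 nM, which is a limit of the assay rather than a number. Among the compounds with values here, the one measured step is an at least 2.6-fold higher number from compound 2 to compound 3 (0.41 log units; beyond the scatter), a swap of the whole group on the nitrogen; how large it truly is cannot be settled because of the limit of > 4000 nM in this assay, at which 1 of the 3 values shown sits.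

Compound 4 `CCCc1ccc(NC2=CC(=O)c3nc4n(c3C2=O)[C@H]2OC[C@@H](O)[C@H]2OC4)cc1` differs from compound 1 in a smaller way: ethyl in place of hydrogen on a saturated chain carbon bound to an aromatic carbon. Within the data shown here, no measured step touches the 4-methylphenyl group, so the change from compound 1 to compound 4 has no direct precedent among the measured compounds, and a step within the scatter is the expectation. Compound 4 is therefore estimated at 1500 nM in this assay, with a range from 700 nM to 3500 nM. That estimate amounts to an expected step of a 1.1-fold higher number from compound 1 to compound 4 (0.02 log units; within the scatter).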

Compound 4, half-maximal inhibitory concentration: 1560 nM
Compound 4: the middle estimate sits 1.0-fold (0.02 log units) below what was measured, within the range that was stated.
By their numbers in this assay, from the lowest: compounds 1, 2 and 4 (each within the scatter of the next). At a limit, above all of these: compound 3.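

Going from the 4-methylphenyl group to the 4-propylphenyl group in this assay gives a 1.1-fold higher number from compound 1 to compound 4 (0.04 log units; within the scatter) and so the two numbers cannot be told apart. The earlier compounds shown here held no measured change at this saturated chain carbon bound to an aromatic carbon, and this one shows that ethyl can take the place of hydrogen there, adding 2 carbon atoms, without a step beyond the scatter on this read-out. Nothing shown gives a reason for this result.

From the compounds shown here alone, whether that holds for larger or different groups stays open: a longer chain such as hexyl, or a chain ending in an amine or a carboxylic acid, could stand in place of the propyl group. How such groups would read in this assay cannot be told from these compounds.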